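Mirror-image pair of dihydropyridine esters in the ileum

The compounds below may be only part of what the source reports. "The series", "measured", "known", "first", "only" and "open" are said of these compounds alone.

Compound 1 `CO/C(O)=C1\C(C)=NC(C)=C(C(=O)OC[C@@H]2CCCO2)[C@H]1c1ccccc1[N+](=O)[O-]`: 0.96 nM
Compound 2 `CO/C(O)=C1\C(C)=NC(C)=C(C(=O)OC[C@H]2CCCO2)[C@@H]1c1ccccc1[N+](=O)[O-]`: 11.1 nM
Compound 3 `COC(=O)C1=C(C)NC(C)=C(C(=O)OC[C@@H]2CCCO2)[C@@H]1c1ccccc1[N+](=O)[O-]`: 24.8 nM

These three compounds were tested in a functional assay (ileum) for binding affinity, with Cavia porcellus as the target; a lower number here means a stronger inhibitor, a higher number a weaker inhibitor. Among them compound 3 gives the highest number, 24.8 nM, that is the weakest inhibition of the three; compound 2 stands nearest to it, while compound 1 lies furthest away with the strongest inhibition.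

The unmeasured compound 4 `COC(=O)C1=C(C)NC(C)=C(C(=O)OC[C@H]2CCCO2)[C@H]1c1ccccc1[N+](=O)[O-]` keeps every atom and bond of compound 3 and changes only the configuration: the two compounds have the same atoms and bonds and differ only in configuration as drawn: 2 of 2 stereo elements differ (all stereocentres are inverted: mirror images); a stereocentre at a saturated ring carbon is drawn S in compound 3 and R in compound 4; a stereocentre at a saturated ring carbon is drawn R in compound 3 and S in compound 4. Compound 4 is therefore the mirror image of compound 3.

Among the compounds with values here, only one measured step speaks to such a change. Compounds 1 and 2 differ only in the configuration as drawn (the fact that compounds 1 and 2 differ only in the configuration as drawn), and that pair showed a 12-fold higher number from compound 1 to compound 2 (1.06 log units; beyond the scatter). Configuration alone can thus shift the number strongly in this assay. For compound 4 a step beyond the scatter is expected as well; since compound 3 already gives the highest number among the three, the more likely direction is toward stronger inhibition, though the data cannot fix the direction with confidence. The expected step is a 4.1-fold lower number from compound 3 to compound 4 (0.62 log units; beyond the scatter). Compound 4 is estimated at 6 nM, within a range from 1.2 nM to 40 nM.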

Compound 4, inhibition constant: 2.04 nM
Beside the measured number, compound 4's estimate is 2.9-fold (0.47 log units) above it, within the range that was stated.
By their numbers in this assay, from the lowest: compound 1; then compound 4; then compound 2; then compound 3.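

In this assay, inverting every stereocentre while leaving all atoms and bonds in place gives a 12-fold lower number from compound 3 to compound 4 (1.08 log units; beyond the scatter). Within the data shown here, this is the first complete mirror-image pair here, so the whole step can be traced to the arrangement of the molecule in space: the fact that compounds 3 and 4 differ only in the configuration as drawn The earlier pair gave a 12-fold higher number from compound 1 to compound 2 (1.06 log units; beyond the scatter), which is also classed as large, so the two pairs together show that configuration alone can move the number strongly in this assay, and in each pair one partner is clearly the stronger inhibitor.

Among these compounds, both stereocentres change together in each pair, which leaves open whether one centre carries most of the step or both contribute, and a compound with only one centre inverted from compound 3 would be needed to separate them. As far as these compounds go, it is also open whether a gap of this size would persist if an amine or a longer chain stood on the ester in place of its saturated ring.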